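This account rests on a few compounds, and the source may have more. Where it says the series, first, only, none or still open, it means among the compounds named here.

Measured so far in a functional assay on KB cells (Homo sapiens) for antiproliferative activity, read by sulforhodamine B assay, with a stated time of 3 days; a higher number here means that more compound is needed for the effect, a lower number that less compound is needed:
compound 1, `CCC1=C(O)c2c(oc(-c3ccc(C(C)C)cc3)cc2=O)C(CC)(CC)C1=O`: 8.13 uM
compound 2, `CCC1=C(O)c2c(oc(-c3ccc(OC)cc3C)cc2=O)C(CC)(CC)C1=O`: 20.9 uM

For the measured compounds named here, compound 2 holds the higher of the two numbers; the only step is a 2.6-fold higher number from compound 1 to compound 2 (0.41 log units; beyond the scatter), a modest shift on exchange of one aryl group for another at the same aromatic carbon.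

Compound 3, `CCC1=C(O)c2c(oc(-c3cccc(C)c3C)cc2=O)C(CC)(CC)C1=O`, is not yet measured. Its change from compound 2 is 2,3-dimethylphenyl in place of 4-methoxy-2-methylphenyl on an aromatic carbon.

Going by the values given here, only that single step bears on the new change, and it concerns the same position, so an aryl swap here has so far moved this assay modestly. Nothing measured distinguishes a 2,3-dimethylphenyl from the other aryl groups, so no direction can be drawn; compound 3 is expected to sit near compound 2, with a 1.4-fold lower number from compound 2 to compound 3 (0.14 log units; within the scatter) not beyond the scatter. The estimate for compound 3 in this assay is 15 uM, within 6 uM to 40 uM.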

Compound 3, concentration for half-maximal effect: 3.1 uM
Beside the measured number, compound 3's estimate is 4.8-fold (0.68 log units) above it; measured number outside the range, below it.
By their numbers in this assay, from the lowest: compound 3; then compound 1; then compound 2.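

In this assay the 2,3-dimethylphenyl group gives the lowest number of the three, with a 6.7-fold lower number from compound 2 to compound 3 (0.83 log units; beyond the scatter) on exchange for 4-methoxy-2-methylphenyl and a 2.6-fold lower number from compound 1 to compound 3 (0.42 log units; beyond the scatter) on exchange for 4-isopropylphenyl. Compound 1 now lies between the other two, so a change of aryl group at this carbon, next to the ring oxygen, can move the number in either direction from compound 1. No available evidence explains the size or direction of these steps.

From the compounds shown here alone, the step from compound 2 removes a methoxy group and adds a methyl group together, so the share of each in the shift stays open. Also open, going by these compounds, is how this carbon responds to a phenyl ring bearing an amine or a carboxylic acid, or to a pyridine ring in place of the phenyl.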